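A few compounds are considered here, and "the series" means these few. Any claim that something is new, unique, unknown or untested is made for them only; others in the source may bear on it.

Of the compounds shown here, three built on one shared core have been measured. Compound 1, `Cc1ccccc1Nc1nc(Nc2ccccc2)ncc1Cl`, is the smallest. In a functional assay on Jurkat cells (Homo sapiens) for inhibition, read by CCK-8 assay, with a stated time of 48 h (a higher number here means a weaker inhibitor of growth, a lower number a stronger inhibitor of growth), compound 1 gives only > 100000 nM, which is a limit of the assay and not a number; this is the limit of > 100000 nM in this assay, at which 1 of the 3 values shown sits. Compound 2, `Cc1ccccc1Nc1nc(Nc2ccc(N3CCN(C(=O)OC(C)(C)C)CC3)cc2)ncc1Cl`, gives 5120 nM in this assay. Compound 3, `CN1CCN(c2ccc(Nc3ncc(Cl)c(NCc4ccc(C(F)(F)F)cc4)n3)nc2)CC1`, gives 7960 nM in this assay. Among the compounds with values here, of the two numbers known, compound 3 holds the higher one, but the gap to compound 2 lies within the usual scatter, so the two cannot be told apart on these data.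

Compound 4, `COc1cccc(Nc2nc(Nc3ccc(N4CCN(C)CC4)cn3)ncc2Cl)c1`, has not yet been measured. It differs from compound 3 by 3-methoxyphenyl in place of 4-(trifluoromethyl)benzyl on a nitrogen on an aromatic ring. Within the data shown here, with no measured pair that isolates this change, the expected step in this assay is small: the step from compound 3 to compound 4 is estimated at a 2.3-fold lower number from compound 3 to compound 4 (0.36 log units; beyond the scatter), leaning gently toward stronger inhibition. The value expected for compound 4 is 3500 nM, most likely falling between 900 nM and 14000 nM.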

Compound 4, concentration for 50% growth inhibition: 15800 nM
Beside the measured number, compound 4's estimate is 4.5-fold (0.65 log units) below it, and the stated range ends below it.
By their numbers in this assay, from the lowest: compounds 2, 3 and 4 (each within the scatter of the next, the first and the last beyond it). At a limit, above all of these: compound 1.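

In this assay, putting 3-methoxyphenyl in place of 4-(trifluoromethyl)benzyl on a nitrogen on an aromatic ring gives a 2.0-fold higher number from compound 3 to compound 4 (0.30 log units; within the scatter), so this single swap leaves the two compounds indistinguishable. Within the data shown here, this is the first pair to isolate a change at this position, and it shows that the group there can be exchanged for one with fewer heavy atoms and a hydrogen-bond acceptor without a readable shift in the number. Nothing measured here offers a reason for this result.

The swap alters several features at once, so this pair cannot show what each contributes on its own. From the compounds shown here alone, it also remains open whether an amine or a carboxylic acid on this aromatic ring, or a longer chain on this nitrogen, would move the number beyond the scatter.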